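Chalcone-triazole-coumarin hybrids: aryl change at the enone terminus

The compounds below may be only part of what the source reports. "The series", "measured", "known", "first", "only" and "open" are said of these compounds alone.

Measured so far in a functional assay on PC-3 cells (Homo sapiens) for inhibition, read by sulforhodamine B assay, with a stated time of 48 h, tested at 50 uM; on this read-out higher numbers stand for more inhibition of growth at the one concentration tested and lower numbers for less inhibition of growth:
compound 1 `COc1cc(/C=C/C(=O)/C=C/c2cc(OC)c(OC)c(OC)c2)ccc1OCc1cn(CCOc2cc(=O)oc3ccccc23)nn1`: 22%
compound 2 `COc1ccccc1/C=C/C(=O)/C=C/c1ccc(OCc2cn(CCCCOc3cc(=O)oc4ccccc34)nn2)c(OC)c1`: "not active" (no number reported)
compound 3 `COc1cc(/C=C/C(=O)/C=C/c2ccccc2)ccc1OCc1cn(CCOc2cc(=O)oc3ccccc23)nn1`: 10%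

Compound 2 stands outside the numbers: it is reported only as "not active" (no number reported), with no figure, so it sits at or below the weakest measured value of the series. Compound 4 `COc1cc(/C=C/C(=O)/C=C/c2cccs2)ccc1OCc1cn(CCCCOc2cc(=O)oc3ccccc23)nn1` differs from compound 2 by thiophen-2-yl in place of 2-methoxyphenyl on a double-bonded chain carbon bound to a double-bonded chain carbon. Among the compounds with values here, the one measured step at the same place is a number 12 percentage points lower from compound 1 to compound 3 (beyond the scatter), a modest loss when a substituted phenyl is replaced by a bare phenyl. Within the data shown here, no step covers a thiophene, and the starting point here is a compound without a number, so no direction beyond the scatter can be expected in this assay; a low reading, possibly again reported as inactive, is the working assumption. Compound 4 is therefore estimated at 10%, in a range of 0% to 25%.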

Compound 4, percent growth inhibition at one concentration: "not active" (no number reported)
The entry for compound 4 holds no number; the estimate stays without a comparison.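

In this assay compound 2 gives "not active" (no number reported) and compound 4 gives "not active" (no number reported), so no new step can be read from this pair. From the compounds shown here alone, whether thiophen-2-yl in place of 2-methoxyphenyl shifts growth inhibition at all stays open. Nothing at hand bears on a cause for this result.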